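From 3,5-dimethylphenyl to phenyl on a carbonyl carbon

The source may report more compounds than this note shows. Statements on the series, on what has been measured and on what is new or still open speak of the compounds shown alone.

Among the measured compounds shown here, in a functional assay on SK-N-AS cells (Homo sapiens) for antiproliferative activity, with a stated time of 72 h (on this read-out higher numbers stand for weaker inhibition and lower numbers for stronger inhibition), compound 1 `Cc1ccc(NC(=O)CCN(Cc2ccc(C(=O)NO)cc2)C(=O)c2cc(C)cc(C)c2)cc1` gives 220 nM, the lower of the two numbers so far, and compound 2 `Cc1cc(C)cc(C(=O)N(CCC(=O)NCc2ccccc2)Cc2ccc(C(=O)NO)cc2)c1` gives 1860 nM. Compound 3 `Cc1ccc(NC(=O)CCN(Cc2ccc(C(=O)NO)cc2)C(=O)c2ccccc2)cc1` differs from compound 1 by phenyl in place of 3,5-dimethylphenyl on a carbonyl carbon. For the measured compounds named here, the only measured step, an 8.5-fold higher number from compound 1 to compound 2 (0.93 log units; beyond the scatter), concerns an amide-type nitrogen instead, so it offers little guidance and no measured step covers this change. No shift beyond the scatter is expected, and the estimated step is a 1.4-fold higher number from compound 1 to compound 3 (0.13 log units; within the scatter). The estimate for compound 3 is 300 nM, with an expected range of 110 nM to 800 nM.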

Compound 3, half-maximal inhibitory concentration: 620 nM
Estimate against measurement, compound 3: 2.1-fold (0.32 log units) below, within the range that was stated.
By their numbers in this assay, from the lowest: compound 1; then compound 3; then compound 2.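

Putting phenyl in place of 3,5-dimethylphenyl on this carbonyl carbon gives a 2.8-fold higher number from compound 1 to compound 3 (0.45 log units; beyond the scatter), so in this assay this position also matters, which the earlier pair, differing only on an amide-type nitrogen, could not show. The aromatic ring stays and only its substituents go, yet the step lies beyond the scatter. No measurement shown explains this shift.

On these data alone, whether an amine or a carboxylic acid on this ring would lower the number remains open. So does whether the same change would give a similar step in compound 2.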